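Swapping the Thiocarbonyl Substituent of Compound 1

This account rests on a few compounds, and the source may have more. Where it says the series, first, only, none or still open, it means among the compounds named here.

Compound 1 `COCCSC(=S)SCC(=O)c1ccc(OC)cc1`: 2130 nM
Compound 2 `CCSC(=S)SCC(=O)c1ccc(-c2ccc(N)cn2)s1`: 43 nM
Compound 3 `CCSC(=S)SCC(=O)c1cccc(CNC(C)=O)c1`: 816 nM

These three values come from an assay on HEK293 cells for inhibition of protein deacetylase HDAC6 (Homo sapiens); a lower number here means a stronger inhibitor, a higher number a weaker inhibitor. Within that set, compound 1 stands highest: compound 3 lies nearest, its number below that of compound 1 by more than the scatter, and compound 2 lies furthest, well beyond the scatter. Compound 4 `CCOC(=S)SCC(=O)c1ccc(OC)cc1` differs from compound 1 in one place: ethoxy in place of (2-methoxyethyl)sulfanyl on a thiocarbonyl carbon. Among the compounds with values here, no pair among the measured compounds isolates this change, so nothing measured shows how this assay responds to it. The step from compound 1 to compound 4 is therefore expected to be small, a 1.2-fold higher number from compound 1 to compound 4 (0.07 log units; within the scatter), in no firm direction and not beyond the scatter. Compound 4 is expected to give about 2500 nM in this assay, within a range from 800 nM to 8000 nM.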

Compound 4, half-maximal inhibitory concentration: 448 nM
Estimate against measurement, compound 4: 5.6-fold (0.75 log units) above; measured number below the stated range.
By their numbers in this assay, from the lowest: compound 2; then compounds 4 and 3 (each within the scatter of the next); then compound 1.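

In this assay the thiocarbonyl carbon turns out to be a place that responds: ethoxy in place of (2-methoxyethyl)sulfanyl gives a 4.8-fold lower number from compound 1 to compound 4 (0.68 log units; beyond the scatter) with the rest of the structure unchanged. Within the data shown here, none of the earlier compounds formed a pair isolating any change, so this is the only direct reading at this position. Nothing available explains the step.

The change swaps the linking sulfur for oxygen and shortens the chain together, so the two remain unseparated. From the compounds shown here alone, an ethylsulfanyl group on the same carbon would tell them apart, and whether an amine or a longer alkoxy chain is tolerated there stays open.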